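A few compounds are considered here, and "the series" means these few. Any claim that something is new, unique, unknown or untested is made for them only; others in the source may bear on it.

Compound 1 `Clc1ccc(-c2noc(-c3cc4ccccc4[nH]3)n2)cc1`: > 50000 nM
Compound 2 `COc1ccc(-c2noc(-c3cc4ccccc4[nH]3)n2)cc1`: > 50000 nM

In a functional assay on MCF7 cells (Homo sapiens) for antiproliferative activity, read by WST assay, with a stated time of 72 h (on this read-out lower numbers stand for stronger inhibition and higher numbers for weaker inhibition), compound 1 reaches only a limit of the assay, > 50000 nM. Compound 2 likewise sits at a limit, > 50000 nM. The step that the two limits leave unreadable from compound 1 to compound 2 cannot be read, as the limit of > 50000 nM in this assay, at which 2 of the 2 values shown sit, shows both values at the same limit. Compound 3 `COc1ccc(-c2noc(-c3cc4ccccc4n3C)n2)cc1` differs from compound 2 by methyl in place of hydrogen on an aromatic nitrogen. Going by the values given here, no measured step bears on this change, and compound 2 stands at a limit, so compound 3 is expected to stay near that limit, with a number no higher from compound 2 to compound 3 (the limit leaves the size open) estimated as no step beyond the scatter. The estimate for compound 3 is 50000 nM, between 15000 nM and 150000 nM.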

Compound 3, half-maximal inhibitory concentration: > 50000 nM
Compound 3 ended at the assay's limit; the forecaster's own chance of this, stated with the estimate: 70%; the middle value lies on the limit itself.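

No step from compound 2 to compound 3 can be read, as both sit at the same limit: the limit of > 50000 nM in this assay, at which 3 of the 3 values shown sit.

What the compounds shown leave open is how strongly compound 1, compound 2 and compound 3 each inhibit, and whether either change alters that at all.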